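The source may hold more compounds than are shown below. What is called first, only, known or untested is meant among the compounds shown, and "the series" means these compounds.

In a functional assay on HCT-116 cells (Homo sapiens) for antiproliferative activity, read by MTT assay, with a stated time of 72 h (on this read-out higher numbers stand for weaker inhibition and lower numbers for stronger inhibition), compound 3 (`NC1=NC2(CCSCC2)N(OCCCOc2cccc(Br)c2)C(N)=N1`) gives 1 nM, level with compound 1 (`CC(C)(C)c1ccc(OCCCON2C(N)=NC(N)=NC23CCSCC3)cc1`) at 1 nM, while compound 2 (`NC1=NC2(CCSCC2)N(OCCCOc2ccc(Br)cc2)C(N)=N1`) gives 20 nM. Compound 4 (`COc1ccc(OCCCON2C(N)=NC(N)=NC23CCSCC3)cc1`) differs from compound 3 as follows: 4-methoxyphenyl in place of 3-bromophenyl on an oxygen on a saturated carbon, with 4-methoxyphenyl in place of 3-bromophenyl on an oxygen on a saturated carbon. Within the data shown here, two measured steps bear on this change, both large: a 20-fold lower number from compound 2 to compound 3 (1.30 log units; beyond the scatter) with 3-bromophenyl in place of 4-bromophenyl, and a 20-fold higher number from compound 1 to compound 2 (1.30 log units; beyond the scatter) with bromo in place of tert-butyl on an aromatic carbon. Neither introduces 4-methoxyphenyl, so a moderate rise is expected, smaller than those steps. In this assay the expected step is a 5.0-fold higher number from compound 3 to compound 4 (0.70 log units; beyond the scatter). Compound 4 is estimated at 5 nM, with an expected range of 1 nM to 30 nM.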

Compound 4, half-maximal inhibitory concentration: 70 nM
For compound 4 the middle estimate is 14-fold (1.15 log units) below the measured one; measured number outside the range, above it.
By their numbers in this assay, from the lowest: compounds 1 and 3 (each within the scatter of the next); then compound 2; then compound 4.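

In this assay, the change at this position carries a large penalty: 4-methoxyphenyl in place of 3-bromophenyl gives a 70-fold higher number from compound 3 to compound 4 (1.85 log units; beyond the scatter), and exchanging tert-butyl for methoxy gives a 70-fold higher number from compound 1 to compound 4 (1.85 log units; beyond the scatter). Methoxy in place of bromo gives a modest step, a 3.5-fold higher number from compound 2 to compound 4 (0.54 log units; beyond the scatter), so among compounds 1, 2 and 4 the number rises from tert-butyl through bromo to methoxy. Compound 4 therefore gives the highest number of the four compounds.

No measurement here accounts for these steps. As far as these compounds go, how a nitrile or a carboxylic acid on an aromatic carbon would compare with methoxy remains open.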